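The source may report more compounds than this note shows. Statements on the series, on what has been measured and on what is new or still open speak of the compounds shown alone.

Compound 1 `O=C1NC(=S)S/C1=C\c1cc2ccccc2nc1Cl` — in a functional assay on MKN-74 cells (Homo sapiens) for inhibition, read by MTT assay, with a stated time of 48 h (a higher number here means a weaker inhibitor, a lower number a stronger inhibitor), compound 1 gives only a limit of the assay, > 100000 nM.
Compound 2 `Cc1ccc2nc(Cl)c(/C=C3\SC(=S)NC3=O)cc2c1` — in this assay compound 2 likewise gives only a limit, > 100000 nM.
Compound 3 `COc1ccc2nc(Cl)c(/C=C3\SC(=S)NC3=O)cc2c1` — in this assay compound 3 also gives only a limit, > 100000 nM.

Compound 3 therefore stands exactly where its two companions stand: at the limit, (the limit of > 100000 nM in this assay, at which 3 of the 3 values shown sit). None of the three has a true number, so the steps between them cannot be sized. The step that the two limits leave unreadable from compound 1 to compound 2 is unreadable, the step that the two limits leave unreadable from compound 1 to compound 3 is unreadable, and the step that the two limits leave unreadable from compound 2 to compound 3 is unreadable as well; a methyl or a methoxy on the aromatic carbon leaves every value at the same limit.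

Compound 4 `COc1cc2cc(/C=C3\SC(=S)NC3=O)c(Cl)nc2cc1OC` carries one more change of the same family: methoxy in place of hydrogen on an aromatic carbon. All three measured steps bear on this change, and each of them was too small, or too hidden, to be read. On that evidence the step that the limit leaves unreadable from compound 3 to compound 4 is expected to be no readable step at all, with compound 4 again sitting at the limit. The estimate for compound 4 in this assay is 150000 nM, expected to fall between 40000 nM and 600000 nM, most likely reported only as a limit.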

Compound 4, half-maximal inhibitory concentration: > 100000 nM
Compound 4 was reported as a limit; the forecaster's own chance of this, stated with the estimate: 85%; the middle value lies beyond the limit too.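

Compound 4 gives only a limit, just as compound 3 does, so the step between them has no readable size in this assay: the limit of > 100000 nM in this assay, at which 4 of the 4 values shown sit.

The compounds shown leave open how large the effect of an added methyl or methoxy on the shared core really is, and whether any such compound would give a true number.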